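Swapping an Ester Arm for an Aminophenyl Ring

The compounds below may be only part of what the source reports. "The series", "measured", "known", "first", "only" and "open" are said of these compounds alone.

Of the compounds shown here, three sharing one core have been measured in a functional assay on MDA-MB-435 cells (Homo sapiens) for cytotoxicity, read by MTT assay, with a stated time of 72 h; a higher number here means a weaker inhibitor, a lower number a stronger inhibitor. Compound 1 `COc1cccc(CNC(=O)c2nc(Br)c3cccnc3c2N[C@H]2CC[C@H](N)CC2)c1` gives 7000 nM in this assay. Compound 2 `COC(=O)CNc1c(C(=O)NCc2ccc(F)cc2)nc(Br)c2cccnc12` gives 10000 nM in this assay, a number that differs from compound 1 only within the usual scatter. For compound 3 `N[C@H]1CC[C@H](Nc2c(C(=O)NC3CCCCC3)nc(Br)c3cccnc23)CC1` this assay reports only a limit, > 10000 nM. Within the data shown here, the single measured step, an at least 1.4-fold higher number from compound 1 to compound 3 (0.15 log units; that floor lies within the scatter), changes the group on an amide-type nitrogen, and its size is blurred by the limit (the limit of > 10000 nM in this assay, at which 1 of the 3 values shown sits).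

Compound 4 `Nc1cccc(Nc2c(C(=O)NCc3ccc(F)cc3)nc(Br)c3cccnc23)c1` differs from compound 2 at another place: 3-aminophenyl in place of (methoxycarbonyl)methyl on a nitrogen on an aromatic ring. Among the measured compounds shown here, no measured step changes the group on that aromatic nitrogen, so the one step available does not bear on this change, and no direction can be read from it. The step from compound 2 to compound 4 is therefore expected to be small, a 1.7-fold lower number from compound 2 to compound 4 (0.22 log units; within the scatter). Compound 4 is estimated at 6000 nM in this assay, with a range from 1500 nM to 20000 nM.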

Compound 4, half-maximal inhibitory concentration: 8000 nM
For compound 4 the middle estimate is 1.3-fold (0.12 log units) below the measured one, within the range that was stated.
By their numbers in this assay, from the lowest: compounds 1, 4 and 2 (each within the scatter of the next).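

Among these compounds, the swap gives a 1.3-fold lower number from compound 2 to compound 4 (0.10 log units; within the scatter) in this assay, the first measured change of the group on this nitrogen on an aromatic ring. So a ringless ester arm and a 3-aminophenyl ring, which share no ring, double bond or hydrogen-bond donor count, cannot be told apart in this read-out, and neither can be ranked above the other at this position. Nothing measured on these two groups bears on this result.

From the compounds shown here alone, it remains open whether a carboxylic acid, a plain phenyl ring, a simple alkyl amine or a longer chain at this nitrogen would move the number beyond the scatter. Going by these compounds, it is also open whether the same swap would read alike with the cyclohexyl or 3-methoxybenzyl group on the amide nitrogen.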